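Taking the methoxy group off compound 3

A few compounds are considered here, and "the series" means these few. Any claim that something is new, unique, unknown or untested is made for them only; others in the source may bear on it.

In a functional assay on HeLa cells (Homo sapiens) for cytotoxicity, read by sulforhodamine B assay, with a stated time of 72 h (a lower number here means a stronger inhibitor, a higher number a weaker inhibitor), compound 1 `COc1cc(NC(=O)/C=C/c2cccc(OC(F)(F)F)c2)cc(OC)c1OC` gives 4400 nM, compound 2 `COc1cc(NC(=O)/C=C/c2cccc(O)c2)cc(OC)c1OC` gives 18700 nM and compound 3 `COc1cccc(/C=C/C(=O)Nc2cc(OC)c(OC)c(OC)c2)c1` gives 11300 nM. Compound 3 belongs to the higher pair of numbers, with a 1.7-fold lower number from compound 2 to compound 3 (0.22 log units; within the scatter) and a 2.6-fold higher number from compound 1 to compound 3 (0.41 log units; beyond the scatter). Compound 4 `COc1cc(NC(=O)/C=C/c2ccccc2)cc(OC)c1OC` loses the whole group: hydrogen in place of methoxy on an aromatic carbon. The measured steps only exchange what sits on the oxygen, and none removes that oxygen. The largest of them is still modest, at a 4.3-fold higher number from compound 1 to compound 2 (0.63 log units; beyond the scatter). In this assay, no step beyond the scatter is therefore expected, in either direction. The expected change is a 1.2-fold higher number from compound 3 to compound 4 (0.06 log units; within the scatter). Compound 4 is estimated at 13000 nM, with an expected range of 5500 nM to 30000 nM.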

Compound 4, half-maximal inhibitory concentration: > 50000 nM
Compound 4 ended at the assay's limit (the forecaster's own chance of this, stated with the estimate: 10%); middle value at least 3.8-fold (0.58 log units) away from the limit.
By their numbers in this assay, from the lowest: compound 1; then compounds 3 and 2 (each within the scatter of the next). At a limit, above all of these: compound 4.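

In this assay compound 4 stands at a limit, not at a number: the limit of > 50000 nM in this assay, at which 1 of the 4 values shown sits. The earlier compounds shown here only exchanged what sits on the oxygen, whereas this change removes the group altogether and leaves a plain phenyl, giving an at least 4.4-fold higher number from compound 3 to compound 4 (0.64 log units; beyond the scatter), an at least 2.6-fold higher number from compound 2 to compound 4 (0.42 log units; beyond the scatter) and an at least 11-fold higher number from compound 1 to compound 4 (1.05 log units; beyond the scatter). All three oxygen-bearing groups therefore give lower numbers than hydrogen at this place.

From the compounds shown here alone, how far compound 4 lies past the limit remains open, so these steps have no upper size. Also open, going by these compounds, is whether the oxygen itself matters, which a group without it, such as an amine or a chlorine atom, could test.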